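The source may hold more compounds than are shown below. What is called first, only, known or untested is meant among the compounds shown, and "the series" means these compounds.

Measured compounds:
compound 1 `N#CC1=C(N)Oc2c(c3nc4ccccc4nc3c3ccccc23)C12C(=O)N(Cc1cnnn1-c1ccc(N)cc1)c1ccccc12` — > 50000 nM
compound 2 `Cc1cccc(-n2nncc2CN2C(=O)C3(C(C#N)=C(N)Oc4c(N)cc5nc6ccccc6nc5c43)c3ccccc32)c1` — > 50000 nM

In an ADME assay on L02 cells (Homo sapiens) for antiproliferative activity, read by MTT assay, with a stated time of 48 h (on this read-out higher numbers stand for weaker inhibition and lower numbers for stronger inhibition), compound 1 gives > 50000 nM, a limit of the assay rather than a number. In this assay compound 2 likewise gives > 50000 nM, again a limit and not a number. Among the measured compounds shown here, compound 2 therefore stands at the upper edge of what this assay reports, and the only other value shown sits at the same edge, as seen in the limit of > 50000 nM in this assay, at which 2 of the 2 values shown sit.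

Compound 3 `Cc1cc(C)cc(-n2nncc2CN2C(=O)C3(C(C#N)=C(N)Oc4c(N)cc5nc6ccccc6nc5c43)c3ccccc32)c1` differs from compound 2 by methyl in place of hydrogen on an aromatic carbon. For the measured compounds named here, because both values shown rest at the limit given in the limit of > 50000 nM in this assay, at which 2 of the 2 values shown sit, there is no measured step to judge the size of such a change by, and the account expects no step beyond the scatter for this assay, with compound 3 most likely again reported only as a limit.

For compound 3 the estimate in this assay is 60000 nM, expected between 30000 nM and 150000 nM, which would mean an expected step that the limit leaves unreadable from compound 2 to compound 3.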

Compound 3, half-maximal inhibitory concentration: > 50000 nM
Compound 3 gave a limit, no number (the forecaster's own chance of this, stated with the estimate: 85%); the middle value is on the limit's open side.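

No step from compound 2 to compound 3 can be read in this assay, because both rest at a limit of the assay rather than at a number: the limit of > 50000 nM in this assay, at which 3 of the 3 values shown sit.

The compounds shown leave open how far each lies past that limit, and whether adding this methyl changes the read-out at all.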